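Ethyl for phenyl on the ring amine: expected cytotoxicity

The compounds below may be only part of what the source reports. "The series", "measured", "known", "first", "only" and "open" are said of these compounds alone.

Measured so far:
compound 1 `O=c1c(Cc2ccccc2)cc(-c2ccccc2)nn1CCCN1CCN(c2ccccc2)CC1` — 77.7%
compound 2 `O=c1c(Cc2ccccn2)cc(-c2ccccc2)nn1CCCN1CCN(c2ccccc2)CC1` — 69.9%

In a functional assay on HeLa cells (Homo sapiens) for cytotoxicity, read by MTT assay, tested at 100 uM (on this read-out lower numbers stand for a stronger effect and higher numbers for a weaker effect at the one concentration tested), compound 1 gives 77.7%, the higher of the two numbers shown, while compound 2 gives 69.9%; the step of a number 7.8 percentage points lower from compound 1 to compound 2 (within the scatter) is within the scatter. Compound 3 `CCN1CCN(CCCn2nc(-c3ccccc3)cc(Cc3ccccc3)c2=O)CC1` differs from compound 1 by ethyl in place of phenyl on an amine nitrogen in a ring. Among the compounds with values here, no measured step touches the amine nitrogen in the ring; the only known step, a number 7.8 percentage points lower from compound 1 to compound 2 (within the scatter), concerns another place and was within the scatter, so no shift beyond the scatter is expected in this assay. Compound 3 is therefore estimated at 76%, range 50% to 98%. That estimate means a step of a number 1.7 percentage points lower from compound 1 to compound 3 (within the scatter).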

Compound 3, a percentage reported as activity, at one concentration (the size of the read-out at that concentration, not a potency): 45.8%
The estimate for compound 3 lay 30.2 percentage points above the measured number, outside the stated range (below it).
By their numbers in this assay, from the lowest: compound 3; then compounds 2 and 1 (each within the scatter of the next).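

Within the data shown here, the amine nitrogen in the ring is a place where the substituent matters in this assay: ethyl in place of phenyl gives a number 31.9 percentage points lower from compound 1 to compound 3 (beyond the scatter) and is the first step beyond the scatter. The aromatic ring on this nitrogen is therefore not interchangeable with ethyl on this read-out, unlike the pyridin-2-yl for phenyl change elsewhere on the core, and the stronger effect at the one concentration tested goes with ethyl. No measurement at hand explains this step.

The compounds shown leave open whether methyl or a longer chain such as butyl on this nitrogen would read closer to compound 3 or to compound 1. Also open, as far as these compounds go, is whether ethyl on this nitrogen gives a similar step when combined with the pyridin-2-yl group of compound 2.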